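The source may report more compounds than this note shows. Statements on the series, on what has been measured and on what is new or still open speak of the compounds shown alone.

For the measured compounds named here, in a functional assay on PC-3 cells (Homo sapiens) for cytotoxicity, read by MTT assay, with a stated time of 96 h (a higher number here means a weaker inhibitor, a lower number a stronger inhibitor), compound 1 (`CC[C@H](NC)C(=O)N[C@@H]1C(=O)N2[C@@H](CC[C@@H]1CN)CC[C@H]2C(=O)NC(c1ccccc1)c1ccccc1`) gives 51700 nM as the only actual number so far. Compound 2 (`CC[C@H](N)C(=O)N[C@@H]1C(=O)N2[C@@H](CC[C@@H]1CNC(=O)NCc1ccccc1)CC[C@H]2C(=O)NC(c1ccccc1)c1ccccc1`) is reported at > 100000 nM and that entry is a limit of the assay, not a number. Going by the values given here, compound 1 thus has no measured step to any neighbour, and no measured change can size the next one. Compound 3 (`CC[C@H](NC)C(=O)N[C@@H]1C(=O)N2[C@@H](CC[C@@H]1CCN)CC[C@H]2C(=O)NC(c1ccccc1)c1ccccc1`) carries aminomethyl in place of amino on a saturated chain carbon bound to a saturated ring carbon and the same difference, cut one bond further out, reads aminomethyl to 2-aminoethyl. The rest of the core of compound 1 is unchanged. In this assay no step beyond the usual scatter is expected in either direction, and this expectation rests on compound 1 at 51700 nM alone. The estimated size is a 1.0-fold lower number from compound 1 to compound 3 (0.01 log units; within the scatter) as an expected, not a measured, step. For compound 3 the expected value is 50000 nM with 20000 nM to 100000 nM as the estimated range.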

Compound 3, half-maximal inhibitory concentration: > 100000 nM
Compound 3 ended at the assay's limit (the forecaster's own chance of this, stated with the estimate: 25%); at least 2.0-fold (0.30 log units) between middle value and limit.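

In this assay compound 3 gives > 100000 nM, and that entry is a limit of the assay, not a number. The change from aminomethyl to 2-aminoethyl on a saturated chain carbon bound to a saturated ring carbon reads as an at least 1.9-fold higher number from compound 1 to compound 3 (0.28 log units; that floor lies within the scatter), so this position now has a one-sided result: the change gives no lower number, but its floor does not establish a loss beyond the scatter. The size of that step is bounded by the ceiling of the assay rather than fixed by a second number, and with only one actual value in the series, the ceiling is the main constraint on any reading here: the limit of > 100000 nM in this assay, at which 2 of the 3 values shown sit.

Going by these compounds, the true distance between compound 1 and compound 3 remains open, and compound 2, which differs from compound 1 in more than one place, gives no comparison that can be read. Also open, on these data alone, is how this position responds to a longer chain, a dimethylamino group or a carboxylic acid in place of the primary amine, and whether any such group gives a number clear of the limit.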